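Aryl amide variation and Karpas-1106P cytotoxicity

The compounds below may be only part of what the source reports. "The series", "measured", "known", "first", "only" and "open" are said of these compounds alone.

The series keeps one core and varies the aryl group on a carbonyl carbon, carried by compound 1 `Cc1ccc(S(=O)(=O)N[C@@H](CC(=O)NC(C)(C)C)C(=O)NCCNC(=O)c2cc(Cl)ccn2)cc1`, compound 2 `Cc1ccc(S(=O)(=O)N[C@@H](CC(=O)NC(C)(C)C)C(=O)NCCNC(=O)c2ccc(Cl)cc2)cc1` and compound 3 `Cc1ccc(S(=O)(=O)N[C@@H](CC(=O)NC(C)(C)C)C(=O)NCCNC(=O)c2ccc(F)c(F)c2)cc1`. In an ADME assay on Karpas-1106P cells (Homo sapiens) for cytotoxicity (a lower number here means that less compound is needed, a higher number that more compound is needed for the effect), compound 1 gives > 11100 nM, which is a limit of the assay rather than a number. Compound 2 likewise reaches only the limit, > 11100 nM. Compound 3 also stops at the limit, > 11100 nM. The steps a step that the two limits leave unreadable from compound 1 to compound 2, a step that the two limits leave unreadable from compound 1 to compound 3 and a step that the two limits leave unreadable from compound 2 to compound 3 therefore cannot be read in either size or direction; all that is known of the measured set is the limit of > 11100 nM in this assay, at which 3 of the 3 values shown sit.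

Compound 4 `C#Cc1cccc(C(=O)NCCNC(=O)[C@H](CC(=O)NC(C)(C)C)NS(=O)(=O)c2ccc(C)cc2)c1` is the next variant at the same position: 3-ethynylphenyl in place of 4-chloropyridin-2-yl on a carbonyl carbon. Within the data shown here, no measured step bears on this exchange with a readable size; every aryl swap on that carbonyl carbon so far has left the read-out at the limit, so no step beyond the scatter is expected, and a step that the limit leaves unreadable from compound 1 to compound 4 is expected to remain unreadable in the same way. For compound 4 in this assay the estimated value is 15000 nM, expected to fall between 8000 nM and 40000 nM, most likely reported again only as a limit.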

Compound 4, half-maximal effective concentration: > 11100 nM
Compound 4 was reported as a limit; the forecaster's own chance of this, stated with the estimate: 80%; the middle value does not contradict the limit.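

Compound 4 gives > 11100 nM in this assay, a limit of the assay, so its steps from compound 1, compound 2 and compound 3 cannot be read in size or direction. All the series shows so far is this: the limit of > 11100 nM in this assay, at which 4 of the 4 values shown sit.

The compounds shown leave open whether any aryl group on this carbonyl carbon changes the read-out.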